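This account rests on a few compounds, and the source may have more. Where it says the series, first, only, none or still open, it means among the compounds named here.

Values in a functional assay on HL-60 cells (Homo sapiens) for cytotoxicity, read by CellTiter-Blue, with a stated time of 48 h; on this read-out higher numbers stand for weaker inhibition and lower numbers for stronger inhibition:
- compound 1 `COc1cc(OC)cc(-c2ccc3c(c2)C(CC(=O)OCC2CO2)C(C(=O)OCC2CO2)=C(N)O3)c1`: > 80000 nM (a limit of the assay)
- compound 2 `CCOC(=O)CC1C(C#N)=C(N)Oc2ccc(-c3cc(OC)cc(OC)c3)cc21`: 19600 nM
- compound 3 `C#CCOC(=O)CC1C(C(=O)OCC#C)=C(N)Oc2ccc(-c3cccc(NC)c3)cc21`: 880 nM

Compound 3 holds the lowest of the two actual numbers at 880 nM. The nearest number belongs to compound 2 at 19600 nM, a gap beyond the usual scatter.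

Compound 4 `C#CCOC(=O)CC1C(C(=O)OCC#C)=C(N)Oc2ccc(-c3ccc(NC)cc3)cc21` is the next one to be tested in this assay. It has 4-(methylamino)phenyl in place of 3-(methylamino)phenyl on an aromatic carbon. The two have the same atoms, joined differently.

Among the measured compounds shown here, no measured pair isolates a change of this kind, so the expectation rests on compound 3 alone, at 880 nM. No step beyond the scatter is expected in this assay, with a slight drift toward a higher number as the working guess, and the support for this is thin. The estimated step of a 1.1-fold higher number from compound 3 to compound 4 (0.06 log units; within the scatter) is expected to be small. For compound 4 the estimated value is 1000 nM, with an expected range of 350 nM to 3000 nM.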

Compound 4, half-maximal inhibitory concentration: 2450 nM
For compound 4 the middle estimate is 2.5-fold (0.39 log units) below the measured one; the range from low to high includes it.
By their numbers in this assay, from the lowest: compound 3; then compound 4; then compound 2. At a limit, above all of these: compound 1.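

In this assay, among the compounds shown here, compound 3 and compound 4 form the only pair that differs in one place, and 4-(methylamino)phenyl in place of 3-(methylamino)phenyl gives a 2.8-fold higher number from compound 3 to compound 4 (0.44 log units; beyond the scatter). With the atoms unchanged, how the methylamino group is attached on the phenyl ring is therefore enough to move the number modestly, with the 3-(methylamino)phenyl compound holding the lower value. Nothing measured here accounts for this step.

On these data alone, it remains open whether the step is particular to the methylamino group or would recur with a primary amine, a dimethylamino group or a carboxylic acid on the same phenyl ring. Also open, as far as these compounds go, is how the step behaves with ethyl esters in place of the two alkyne-bearing esters.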